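A few compounds are considered here, and "the series" means these few. Any claim that something is new, unique, unknown or untested is made for them only; others in the source may bear on it.

Measured in a functional assay on DU-145 cells (Homo sapiens) for cytotoxicity, read by trypan blue exclusion, with a stated time of 96 h; a lower number here means a stronger inhibitor, a higher number a weaker inhibitor:
- compound 1 `COc1cc(OC)c(/C=C/S(=O)(=O)Nc2ccc(OC)c(OP(=O)(O)O)c2)c(OC)c1`: 40 nM
- compound 2 `COc1cc(OC)c(/C=C/S(=O)(=O)Nc2ccc(OC)c([N+](=O)[O-])c2)c(OC)c1`: 2500 nM
- compound 3 `COc1cc(OC)c(/C=C/S(=O)(=O)Nc2ccc(F)c([N+](=O)[O-])c2)c(OC)c1`: 100000 nM

Of these three, compound 2 holds the middle place, at 2500 nM. Compound 4 `COC(=O)C(C)Nc1cc(NS(=O)(=O)/C=C/c2c(OC)cc(OC)cc2OC)ccc1OC` has (1-(methoxycarbonyl)ethyl)amino in place of the nitro of compound 2, on an aromatic carbon, ortho to a methoxy group: (1-(methoxycarbonyl)ethyl)amino in place of nitro on an aromatic carbon. Going by the values given here, only one measured step changes that same carbon, a 63-fold higher number from compound 1 to compound 2 (1.80 log units; beyond the scatter), and it shows that the nitro compound has the higher number. The other step, a 40-fold higher number from compound 2 to compound 3 (1.60 log units; beyond the scatter), replaces the methoxy group and leaves the nitro in place, so it shows only that this series can move widely. Among the compounds with values here, no measured compound carries the entering group, so a clear but smaller move toward a lower number is expected in this assay. The expected step is an 8.3-fold lower number from compound 2 to compound 4 (0.92 log units; beyond the scatter). For compound 4 the estimate is 300 nM, with an expected range of 30 nM to 3000 nM.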

Compound 4, half-maximal inhibitory concentration: 100 nM
Estimate against measurement, compound 4: 3.0-fold (0.48 log units) above, within the range that was stated.
By their numbers in this assay, from the lowest: compound 1; then compound 4; then compound 2; then compound 3.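

In this assay, the carbon that holds the nitro of compound 2 also accepts a larger, uncharged chain, with (1-(methoxycarbonyl)ethyl)amino giving a 25-fold lower number from compound 2 to compound 4 (1.40 log units; beyond the scatter). The group of compound 1 is therefore not the only one at this carbon that brings a low number, though it stays ahead, with a 2.5-fold higher number from compound 1 to compound 4 (0.40 log units; beyond the scatter). Nothing available explains this change. The compounds shown leave open whether the gain comes from the amino nitrogen or from the ester, which a plain amine or the corresponding carboxylic acid at this carbon would separate.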